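Phenyl in place of thiophene: expected cytotoxicity of compound 3

The source may hold more compounds than are shown below. What is called first, only, known or untested is meant among the compounds shown, and "the series" means these compounds.

In a functional assay on Ehrlich cells (Mus musculus) for cytotoxicity, tested at 25 ug/mL (on this read-out higher numbers stand for a stronger effect at the one concentration tested and lower numbers for a weaker effect), two compounds have been measured:
Compound 1 `COc1cc(N2C(N)=C(C#N)C(c3cccc([N+](=O)[O-])c3)C3=C2CC(C)(C)CC3=O)cc(OC)c1OC` gives 20%.
Compound 2 `COc1cc(N2C(N)=C(C#N)C(c3cccs3)C3=C2CC(C)(C)CC3=O)cc(OC)c1OC` gives 10%.

Within the data shown here, compound 2 carries the lower of these two numbers, but its only neighbour is compound 1, and the step of a number 10 percentage points lower from compound 1 to compound 2 (within the scatter) lies within the scatter, so the two cannot be told apart on this read-out.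

Compound 3 `COc1cc(N2C(N)=C(C#N)C(c3ccccc3)C3=C2CC(C)(C)CC3=O)cc(OC)c1OC` has not yet been measured. It differs from compound 2 in one place: phenyl in place of thiophen-2-yl on a saturated ring carbon.

Among the measured compounds shown here, the only measured step, a number 10 percentage points lower from compound 1 to compound 2 (within the scatter), also exchanged the group on that same saturated ring carbon, and it stayed within the scatter. Nothing measured suggests that swapping the group at this position moves the numbers, so in this assay no step beyond the scatter is expected for compound 3, that is a number 5 percentage points higher from compound 2 to compound 3 (within the scatter). Compound 3 is therefore estimated at 15%, with a range from 0% to 35%.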

Compound 3, a percentage reported as activity, at one concentration (the size of the read-out at that concentration, not a potency): 6%
Beside the measured number, compound 3's estimate is 9 percentage points above it; the range from low to high includes it.
By their numbers in this assay, from the lowest: compounds 3, 2 and 1 (each within the scatter of the next, the first and the last beyond it).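

In this assay the exchange of thiophen-2-yl for phenyl gives a number 4 percentage points lower from compound 2 to compound 3 (within the scatter) and so does not separate these two rings. Hydrogen in place of nitro on the aromatic ring gives a number 14 percentage points lower from compound 1 to compound 3 (beyond the scatter) and is the first step in this series to pass the scatter, which shows that a change to the group on this saturated ring carbon can register in this read-out, though only modestly. Nothing available explains why this step is larger than the others.

On these data alone, it remains open whether an amine or a chlorine atom in place of the nitro group would keep the number seen for compound 1. As far as these compounds go, it is equally open whether a pyridine ring or a saturated cyclohexyl ring on this carbon would read like phenyl.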